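The source may report more compounds than this note shows. Statements on the series, on what has been measured and on what is new or still open speak of the compounds shown alone.

Compound 1, `CCCNC(=O)c1ccc(Oc2nc(-c3c(C)noc3C)cnc2N)cc1`: 32100 nM
Compound 2, `Cc1noc(C)c1-c1cnc(N)c(Oc2ccc(C(=O)NC3CCCC3)cc2)n1`: 9970 nM
Compound 3, `Cc1noc(C)c1-c1cnc(N)c(Oc2ccc(C(=O)Nc3ccccc3)cc2)n1`: 10500 nM

In a functional assay on HeLa cells (Homo sapiens) for inhibition, read by MTT assay, with a stated time of 72 h (a lower number here means a stronger inhibitor, a higher number a weaker inhibitor), compound 3 gives 10500 nM, the second highest of the three numbers. Its nearest neighbour is compound 2, which lies within the scatter: a 1.1-fold higher number from compound 2 to compound 3 (0.02 log units; within the scatter). The furthest is compound 1: a 3.1-fold lower number from compound 1 to compound 3 (0.49 log units; beyond the scatter).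

Compound 4, `Cc1noc(C)c1-c1cnc(N)c(Oc2ccc(C(=O)Nc3ccc(Cl)cc3)cc2)n1`, differs from compound 3 by chloro in place of hydrogen on an aromatic carbon. For the measured compounds named here, no measured step touches this part of the molecule. The three steps on record all concern the group on the amide nitrogen: a 3.2-fold lower number from compound 1 to compound 2 (0.51 log units; beyond the scatter) and a 3.1-fold lower number from compound 1 to compound 3 (0.49 log units; beyond the scatter) are modest, and a 1.1-fold higher number from compound 2 to compound 3 (0.02 log units; within the scatter) shows that phenyl and cyclopentyl there give numbers within the scatter of each other. What a chloro on the outer phenyl ring does in this assay is therefore not informed by any measured pair. Going by the values given here, with no step of this kind to lean on, the expected change is none beyond the scatter: a 1.2-fold lower number from compound 3 to compound 4 (0.09 log units; within the scatter). The estimate for compound 4 in this assay is 8500 nM, with a range from 3000 nM to 25000 nM.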

Compound 4, half-maximal inhibitory concentration: 2230 nM
Beside the measured number, compound 4's estimate is 3.8-fold (0.58 log units) above it; measured number outside the range, below it.
By their numbers in this assay, from the lowest: compound 4; then compounds 2 and 3 (each within the scatter of the next); then compound 1.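

For the compounds shown here, the outer phenyl ring, untouched by the earlier compounds, proves responsive in this assay: chloro on an aromatic carbon, para to a large group, gives a 4.7-fold lower number from compound 3 to compound 4 (0.67 log units; beyond the scatter), whereas phenyl and cyclopentyl on the amide nitrogen had stayed within the scatter of each other. The 4-chlorophenyl group also separates from cyclopentyl, with a 4.5-fold lower number from compound 2 to compound 4 (0.65 log units; beyond the scatter), and from propyl, with a 14-fold lower number from compound 1 to compound 4 (1.16 log units; beyond the scatter), which makes compound 4 the strongest inhibitor of the four. No supporting measurement is available to explain this change.

The compounds shown leave open whether the shift is particular to chloro or would also appear with fluoro, methyl or methoxy at the same carbon. They also leave open what chloro would do at another carbon of that ring, and how an amine or a carboxylic acid would read there.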